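Ring size and linker on the amide nitrogen

The source may report more compounds than this note shows. Statements on the series, on what has been measured and on what is new or still open speak of the compounds shown alone.

The three measured compounds share one core and differ only in the group on the amide-type nitrogen. Compound 1 `O=C(NC1CCN(C2CC2)C1)c1cc(-c2ccc(NS(=O)(=O)c3cccc(Cl)c3Cl)cc2)nc2[nH]ncc12` gives 610 nM in an assay for inhibition of serine/threonine-protein kinase Sgk1 (Homo sapiens), with stated times of 30 min and 60 min, in the presence of a further agent that is not named here; a higher number here means a weaker inhibitor, a lower number a stronger inhibitor. Compound 2 `CC(C)NC(=O)c1cc(-c2ccc(NS(=O)(=O)c3cccc(Cl)c3Cl)cc2)nc2[nH]ncc12` gives 17600 nM in this assay, which is a 29-fold higher number from compound 1 to compound 2 (1.46 log units; beyond the scatter). Compound 3 `CN1CC(NC(=O)c2cc(-c3ccc(NS(=O)(=O)c4cccc(Cl)c4Cl)cc3)nc3[nH]ncc23)C1` sits at the assay limit of < 1 nM in this assay, so only a limit is known for it (the limit of < 1 nM in this assay, at which 1 of the 3 values shown sits). The steps of an at least 610-fold lower number from compound 1 to compound 3 (2.78 log units; beyond the scatter) and an at least 17000-fold lower number from compound 2 to compound 3 (4.24 log units; beyond the scatter) are both large, so compound 3 stands at the strong end of the numbers shown.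

Compound 4 `CN1CCC(CNC(=O)c2cc(-c3ccc(NS(=O)(=O)c4cccc(Cl)c4Cl)cc3)nc3[nH]ncc23)C1` carries (1-methylpyrrolidin-3-yl)methyl in place of 1-methylazetidin-3-yl on an amide-type nitrogen. The step from compound 1 bears on this, since compound 1 holds a 1-cyclopropylpyrrolidin-3-yl group on the same nitrogen and gives 610 nM. For compound 3, with its 1-methylazetidin-3-yl group, only a limit is known. A return to a five-membered ring, now with a methylene linker, is expected to raise the number beyond the scatter. The expected step is an at least 15-fold higher number from compound 3 to compound 4 (1.17 log units; beyond the scatter). Compound 4 is expected to give about 15 nM in this assay, within a range of 1 nM to 300 nM.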

Compound 4, half-maximal inhibitory concentration: 45 nM
The estimate for compound 4 lay 3.0-fold (0.48 log units) below the measured number; measured number inside the range.
By their numbers in this assay, from the lowest: compound 4; then compound 1; then compound 2. At a limit, below all of these: compound 3.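

A five-membered ring on the amide-type nitrogen is not weak in itself, as the (1-methylpyrrolidin-3-yl)methyl group gives a 14-fold lower number from compound 1 to compound 4 (1.13 log units; beyond the scatter) and a 390-fold lower number from compound 2 to compound 4 (2.59 log units; beyond the scatter). Even so, this group does not match the 1-methylazetidin-3-yl group, with an at least 45-fold higher number from compound 3 to compound 4 (1.65 log units; beyond the scatter). Compound 3 stands at a limit and not at a number, so this last step has only one bound: the limit of < 1 nM in this assay, at which 1 of the 4 values shown sits.

On these data alone, the step between compound 1 and compound 4 changes the methylene linker and the cyclopropyl or methyl group on the ring nitrogen together, so the share of each remains open. A 1-methylpyrrolidin-3-yl group, a (1-methylazetidin-3-yl)methyl group and a 1-methylpiperidin-4-yl group would separate ring size, linker and nitrogen substituent.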